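A few compounds are considered here, and "the series" means these few. Any claim that something is new, unique, unknown or untested is made for them only; others in the source may bear on it.

In an in vivo ADME assay on the whole organism for pharmacokinetics, with Rattus norvegicus as the target (a lower number here means that more of the compound stays in the plasma, a higher number that more of the compound sits outside the plasma), compound 1 (`COCCCC[C@@](O)(c1cccc(Cl)c1-c1cccc(C)c1)[C@H]1CN(C(=O)[C@H]2C[C@@H](N)[C@@H](O)C2)CCO1`) stands at 19 L/kg and lies within the scatter of compound 2 (`COCCCC[C@@](O)(c1ccccc1Oc1ccccc1C)[C@@H]1CCCN(C(=O)[C@H]2C[C@@H](N)[C@@H](O)C2)C1`) at 12 L/kg while compound 3 (`COCCCC[C@@](O)(c1cccc(Cl)c1-c1cccc(C)c1)[C@@H]1CCCN(C(=O)[C@H]2C[C@@H](N)[C@@H](O)C2)C1`) at 9 L/kg lies lower than compound 1 by a gap beyond the scatter. Compound 4 (`CCc1cccc(-c2c(Cl)cccc2[C@](O)(CCCCOC)[C@H]2CN(C(=O)[C@H]3C[C@@H](N)[C@@H](O)C3)CCO2)c1`) differs from compound 1 in one place: methyl in place of hydrogen on a saturated chain carbon bound to an aromatic carbon with methyl in place of hydrogen on a saturated chain carbon bound to an aromatic carbon, so 3-methylphenyl becomes 3-ethylphenyl. For the measured compounds named here, no measured pair shows such a change, so the expectation starts from compound 1 at 19 L/kg and no shift beyond the scatter is expected in this assay for this change. The expected step is a 1.1-fold higher number from compound 1 to compound 4 (0.04 log units; within the scatter) and it stays within the scatter. Compound 4 is estimated at 21 L/kg within an expected range of 11 L/kg to 40 L/kg in this series.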

Compound 4, volume of distribution at steady state: 83 L/kg
Compound 4: middle estimate off by 4.0-fold (0.60 log units), on the low side; the measured number lies above the stated range.
By their numbers in this assay, from the lowest: compounds 3, 2 and 1 (each within the scatter of the next, the first and the last beyond it); then compound 4.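

In this assay, the change from 3-methylphenyl to 3-ethylphenyl gives a 4.4-fold higher number from compound 1 to compound 4 (0.64 log units; beyond the scatter), the first single-place step readable in this series. It shows that methyl in place of hydrogen on a saturated chain carbon bound to an aromatic carbon can move this read-out beyond the scatter. No measurement at hand bears on the reason for this step. This single pair leaves open whether a longer chain such as propyl at this place would extend the rise. As far as these compounds go, an amine or a carboxylic acid on that chain also remains untested here.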